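Swapping a dienoyl amide for a tosyl group on a longer chain

The source may report more compounds than this note shows. Statements on the series, on what has been measured and on what is new or still open speak of the compounds shown alone.

Compound 1 `C/C=C/C=C/C(=O)N[C@H](C(=O)NCCCCCCCCCCCCCC)[C@@H](C)O` carries a long saturated chain on the amide nitrogen. In a functional assay on HepG2 cells (Homo sapiens) for cytotoxicity, read by MTT assay, with a stated time of 48 h (on this read-out higher numbers stand for weaker inhibition and lower numbers for stronger inhibition), compound 1 gives only a limit, > 400000 nM. Compound 2 `CCCCCCCCCCCCCCNC(=O)[C@@H](NS(=O)(=O)c1ccc(C)cc1)[C@@H](C)O` differs by (4-methylphenyl)sulfonyl in place of (penta-1,3-dien-1-yl)carbonyl on an amine nitrogen and in this assay compound 2 gives 10900 nM, so an at least 36-fold lower number from compound 1 to compound 2 (1.56 log units; beyond the scatter). Compound 3 `C/C=C/C=C/C(=O)N[C@H](C(=O)NCCCCCCCCCCCCCCCCCC)[C@@H](C)O` keeps the first amide but its chain is extended, (butyl in place of hydrogen on a saturated chain carbon, ten or more bonds along the chain from an amide-type nitrogen), and in this assay compound 3 gives 284000 nM, so an at least 1.4-fold lower number from compound 1 to compound 3 (0.14 log units; that floor lies within the scatter). Compound 4 `CCCCCCCCCCCCCCCCCCNC(=O)[C@@H](NS(=O)(=O)c1ccc(C)cc1)[C@@H](C)O` is not yet measured; it differs from compound 3 by (4-methylphenyl)sulfonyl in place of (penta-1,3-dien-1-yl)carbonyl on an amine nitrogen, the same change that separates compound 1 from compound 2. Carrying that step over to compound 3, the expected step in this assay is a 36-fold lower number from compound 3 to compound 4 (1.55 log units; beyond the scatter), resting on the change from compound 1 to compound 2. Compound 4 is therefore estimated at 8000 nM, expected to fall between 2500 nM and 30000 nM.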

Compound 4, half-maximal inhibitory concentration: 75800 nM
Compound 4: the middle estimate sits 9.5-fold (0.98 log units) below what was measured; the measured number lies above the stated range.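

On the longer chain, (4-methylphenyl)sulfonyl in place of (penta-1,3-dien-1-yl)carbonyl still lowers the number in this assay, with a 3.7-fold lower number from compound 3 to compound 4 (0.57 log units; beyond the scatter), so the direction carries over between the two cores, but the size does not: the same change on two cores in this assay, an at least 36-fold lower number (1.56 log units; beyond the scatter) from compound 1 to compound 2 and a 3.7-fold lower number (0.57 log units; beyond the scatter) from compound 3 to compound 4, at least 9.7-fold (0.99 log units) apart, beyond the scatter of two such steps

Lengthening the chain also depends on the group present on the amine nitrogen, with a 7.0-fold higher number from compound 2 to compound 4 (0.84 log units; beyond the scatter): the same change on two cores in this assay, an at least 1.4-fold lower number (0.14 log units; that floor lies within the scatter) from compound 1 to compound 3 and a 7.0-fold higher number (0.84 log units; beyond the scatter) from compound 2 to compound 4, at least 9.7-fold (0.99 log units) apart, beyond the scatter of two such steps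

The value of compound 1 is a limit and not a number, so the first step is known only as a floor: the limit of > 400000 nM in this assay, at which 1 of the 4 values shown sits.

The compounds shown do not explain why the step shrinks on the longer chain. On these data alone, it remains open how the same change behaves on a shorter chain, and whether a methylsulfonyl or benzoyl group would follow the same trend.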